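The source may hold more compounds than are shown below. What is called first, only, known or untested is meant among the compounds shown, and "the series" means these compounds.

Two compounds share a core in which an amine-linked aromatic ring carries methoxy groups and a sulfonyl group carries a second aromatic ring. Compound 1 `COc1cc(Nc2nc3ccccc3nc2S(=O)(=O)c2ccccc2)cc(OC)c1OC` has three methoxy groups and a plain phenyl on the sulfonyl; in a functional assay on PC-3 cells (Homo sapiens) for cytotoxicity, read by MTT assay, with a stated time of 72 h (on this read-out higher numbers stand for weaker inhibition and lower numbers for stronger inhibition), compound 1 gives 29100 nM. Compound 2 `COc1cc(Nc2nc3ccccc3nc2S(=O)(=O)c2ccc(C)cc2)cc(OC)c1` has two methoxy groups and a methyl on the sulfonyl phenyl; in this assay compound 2 gives 2940 nM, the lower of the two numbers, separated from compound 1 by a gap well beyond the scatter. Compound 3 `COc1cc(Nc2nc3ccccc3nc2S(=O)(=O)c2ccc(C)cc2)cc(OC)c1OC` keeps the methyl-bearing sulfonyl ring of compound 2 and adds (methoxy in place of hydrogen on an aromatic carbon). For the measured compounds named here, no single-change step between measured compounds exists here, so the expected size of this step rests on compound 1 alone, which carries three methoxy groups and gives 29100 nM. For compound 3 a moderate weakening is expected, a step of a 2.7-fold higher number from compound 2 to compound 3 (0.43 log units; beyond the scatter). Compound 3 is therefore estimated at 8000 nM, within a range from 2500 nM to 25000 nM.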

Compound 3, half-maximal inhibitory concentration: 4850 nM
Beside the measured number, compound 3's estimate is 1.6-fold (0.22 log units) above it; low and high end bracket the measured number.
By their numbers in this assay, from the lowest: compounds 2 and 3 (each within the scatter of the next); then compound 1.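

In this assay the step of methoxy in place of hydrogen, ortho to two methoxy groups and para to a large group, is a 1.6-fold higher number from compound 2 to compound 3 (0.22 log units; within the scatter) which lies within the scatter, so the numbers for these two compounds cannot be told apart and this position accepts the added methoxy. The step of methyl in place of hydrogen on the sulfonyl ring is a 6.0-fold lower number from compound 1 to compound 3 (0.78 log units; beyond the scatter) which lies beyond the scatter, so of these two single changes, only the methyl step is large enough to stand out from the scatter. Nothing measured here accounts for the size of either step.

On these data alone, whether this methoxy position would tolerate an ethoxy group or an amine remains open. So does whether a chlorine or a longer chain on the sulfonyl ring would give a step like that of the methyl.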